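The source may hold more compounds than are shown below. What is called first, only, known or untested is meant among the compounds shown, and "the series" means these compounds.

Compounds measured so far:
compound 1, `Brc1cn2ccnc2c(-c2ccc3ncn(C4CCCCC4)c3c2)n1` — 67.7%
compound 2, `Clc1ccc(-c2cn3ccnc3c(-c3ccc4ncn(C5CCCCC5)c4c3)n2)cc1` — 10.6%

In a functional assay on KM12 cells (Homo sapiens) for inhibition, read by sulforhodamine B assay, with a stated time of 48 h, tested at 10 uM (on this read-out higher numbers stand for more inhibition at the one concentration tested (going by the name of the read-out) and lower numbers for less inhibition), compound 1 gives 67.7%, and compound 2 gives 10.6%. Among the measured compounds shown here, compound 2 therefore stands lowest of the two, with the one step from compound 1 to compound 2, a number 57.1 percentage points lower from compound 1 to compound 2 (beyond the scatter), showing how far an aryl group in place of bromo pulled the number down. Compound 3, `Fc1ccccc1-c1cn2ccnc2c(-c2ccc3ncn(C4CCCCC4)c3c2)n1`, differs from compound 2 by 2-fluorophenyl in place of 4-chlorophenyl on an aromatic carbon. For the measured compounds named here, no measured step compares one aryl group against another at this position; the only step known, from compound 1 to compound 2, concerns bromo against 4-chlorophenyl and bears on the present change only in that both compounds 2 and 3 carry an aryl group there. With compound 2 already low, the account expects for compound 3 a step of a number 7.4 percentage points higher from compound 2 to compound 3 (within the scatter), essentially none beyond the scatter. Compound 3 is thus estimated at 18%, with a range from 0% to 50%.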

Compound 3, a percentage reported as inhibition, at one concentration (the size of the read-out at that concentration, not a potency): 2.45%
Compound 3: middle estimate off by 15.6 percentage points, on the high side; the measured number falls inside the stated range.
By their numbers in this assay, from the lowest: compounds 3 and 2 (each within the scatter of the next); then compound 1.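

In this assay, putting 2-fluorophenyl in place of 4-chlorophenyl gives a number 8.2 percentage points lower from compound 2 to compound 3 (within the scatter), so these two aryl groups are not told apart at this position, despite carrying different halogens at different places on the ring. The second aryl group also gives a number 65.3 percentage points lower from compound 1 to compound 3 (beyond the scatter), which shows that the large gap from the bromo compound is not peculiar to 4-chlorophenyl but holds for both aryl groups shown. Nothing at hand accounts for that gap.

The compounds shown leave open whether any aryl group at this position would stay as far from compound 1, for instance a phenyl ring bearing an amine or a carboxylic acid. They also leave open how a non-aryl group there, such as a morpholine or a short alkyl chain, would compare with bromo.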